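This account rests on a few compounds, and the source may have more. Where it says the series, first, only, none or still open, it means among the compounds named here.

Of the compounds shown here, three have so far been tested in an ADME assay on HEK293 cells (Homo sapiens) for cytotoxicity, read by CellTiter-Glo and resazurin assay, with a stated time of 72 h; on this read-out lower numbers stand for an effect already at smaller amounts and higher numbers for an effect only at larger amounts of compound. Compound 1 `CC(C)N(Cc1cccc(OCCCCCC(=O)O)c1)C(=O)c1ccc(-c2cccc(OCc3ccccc3)c2)cc1` gives > 26000 nM, which is a limit of the assay. Compound 2 `CCOC(=O)CCCCCOc1cccc(CN(C(=O)c2ccc(-c3cc4ccccc4n3S(=O)(=O)c3ccccc3)cc2)C(C)C)c1` likewise gives only a limit, > 26000 nM. Compound 3 `CCCN(Cc1ccc(OCCCCCC(=O)OCC)cc1)C(=O)c1ccc(Br)cc1` also sits at a limit, > 26000 nM. For the measured compounds named here, no measured pair differs in a single place, so no step is known; the whole picture is summed up by the limit of > 26000 nM in this assay, at which 3 of the 3 values shown sit. Compound 4 `CCCNCc1ccc(OCCCCCC(=O)OCC)cc1` is not yet measured and differs from compound 3 by hydrogen in place of (4-bromophenyl)carbonyl on an amine nitrogen. Going by the values given here, with every value so far at the limit, no step beyond the scatter is expected, and a limit rather than a number is again the likely outcome. Compound 4 is accordingly estimated at 30000 nM, within 15000 nM to 80000 nM, the expected step being a step that the limit leaves unreadable from compound 3 to compound 4.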

Compound 4, half-maximal effective concentration: > 26000 nM
Compound 4 was reported as a limit; the forecaster's own chance of this, stated with the estimate: 85%; the middle value is on the limit's open side.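

Compound 3 and compound 4 both stand at a limit in this assay, and the step between them cannot be read. The compounds shown leave open at what concentration, if any, a member of the series affects these cells: the limit of > 26000 nM in this assay, at which 4 of the 4 values shown sit.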